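The compounds below may be only part of what the source reports. "The series", "measured", "known", "first", "only" and "open" are said of these compounds alone.

Compound 1 `S=C(Nc1ccc(Cl)cc1)OCCc1ccccc1` was tested in an ADME assay on MT4 cells (Homo sapiens) for cytotoxicity, read by MTT assay (on this read-out higher numbers stand for lower toxicity in this test and lower numbers for higher toxicity in this test), and here compound 1 gives only a limit, > 100000 nM. Compound 2 `O=[N+]([O-])c1ccc(NC(=S)OCCc2ccccc2)cc1`, which carries a nitro in place of chloro on an aromatic carbon, likewise reaches only a limit in this assay, > 100000 nM. The step from compound 1 to compound 2 is therefore a step that the two limits leave unreadable from compound 1 to compound 2, as both sit at the limit of > 100000 nM in this assay, at which 2 of the 2 values shown sit. Compound 3 `S=C(Nc1ccc(Cl)cc1)OCCc1ccncc1` differs from compound 1 by pyridin-4-yl in place of phenyl on a saturated chain carbon, two bonds along the chain from an oxygen on an unsaturated carbon. With no readable step to draw on, compound 3 is expected to stay near the limit, a step that the limit leaves unreadable from compound 1 to compound 3, giving an estimate of 150000 nM within 60000 nM to 400000 nM.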

Compound 3, half-maximal cytotoxic concentration: 70000 nM
The estimate for compound 3 lay 2.1-fold (0.33 log units) above the measured number, within the range that was stated.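

For the compounds shown here, compound 3 is the first compound here to give a real number rather than a limit in this assay, so this place on the chain is the first to show a readable result: the limit of > 100000 nM in this assay, at which 2 of the 3 values shown sit. Pyridin-4-yl in place of phenyl gives an at least 1.4-fold lower number from compound 1 to compound 3 (0.15 log units; that floor lies within the scatter) and so points toward more toxicity in this test. The true step may be larger, but its floor alone does not show a change beyond the scatter. Still open, on these data alone, is whether a piperidine ring or a longer chain at this place would give a lower number. Also open, as far as these compounds go, is whether pyridin-4-yl would act the same way on the nitro compound 2.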